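This account rests on a few compounds, and the source may have more. Where it says the series, first, only, none or still open, it means among the compounds named here.

Measured in a physicochemical assay for metabolic stability, read by HPLC; on this read-out lower numbers stand for a shorter-lived compound and higher numbers for a longer-lived compound:

- compound 1 `Cc1cn([C@H]2C[C@H](N=[N+]=[N-])[C@@H](COP(=O)(O)Oc3ccc(Br)cc3)O2)c(=O)[nH]c1=O`: 7.97 h
- compound 2 `Cc1cn([C@H]2C[C@H](N=[N+]=[N-])[C@@H](COP(=O)(O)Oc3ccncc3)O2)c(=O)[nH]c1=O`: 8.07 h
- compound 3 `Cc1cn([C@H]2C[C@H](N=[N+]=[N-])[C@@H](COP(=O)(O)Oc3ccc(Cl)cc3)O2)c(=O)[nH]c1=O`: 5.5 h

The three compounds share one core and differ only in the group on an oxygen. Compound 3 stands within the scatter of both of the others, as the two steps that reach it show: a 1.4-fold lower number from compound 1 to compound 3 (0.16 log units; within the scatter), and a 1.5-fold lower number from compound 2 to compound 3 (0.17 log units; within the scatter). On these numbers, the three cannot be put in any firm order.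

The next compound, compound 4 `Cc1cn([C@H]2C[C@H](N=[N+]=[N-])[C@@H](COP(=O)(O)Oc3cncc(Cl)c3)O2)c(=O)[nH]c1=O`, has not yet been measured. Its difference from compound 3 is 5-chloropyridin-3-yl in place of 4-chlorophenyl on an oxygen. In short, 5-chloropyridin-3-yl stands in place of 4-chlorophenyl on an oxygen.

The closest precedents are the two steps that exchange a ring of carbon only for a ring with a hetero atom, or the reverse: a 1.0-fold higher number from compound 1 to compound 2 (0.01 log units; within the scatter), and a 1.5-fold lower number from compound 2 to compound 3 (0.17 log units; within the scatter). Neither left the scatter, and the halogen exchange in the step of a 1.4-fold lower number from compound 1 to compound 3 (0.16 log units; within the scatter) did not either. These few steps give no firm direction, so no change beyond the scatter is expected in this assay. The expected step is a 1.2-fold higher number from compound 3 to compound 4 (0.07 log units; within the scatter).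

Compound 4 is estimated at 6.5 h, with an expected range of 3.5 h to 11 h.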

Compound 4, half-life: 7.27 h
Compound 4: the middle estimate sits 1.1-fold (0.05 log units) below what was measured; measured number inside the range.
By their numbers in this assay, from the lowest: compounds 3, 4, 1 and 2 (each within the scatter of the next).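

In this assay, 5-chloropyridin-3-yl in place of 4-chlorophenyl on an oxygen brings a ring with one hetero atom and one hydrogen-bond acceptor in place of a ring of carbon only, and the result stays inside the scatter (a 1.3-fold higher number from compound 3 to compound 4 (0.12 log units; within the scatter)). The new group also stays within the scatter of both other groups on this oxygen, whether it replaces pyridin-4-yl (a 1.1-fold lower number from compound 2 to compound 4 (0.05 log units; within the scatter)) or 4-bromophenyl (a 1.1-fold lower number from compound 1 to compound 4 (0.04 log units; within the scatter)). The earlier compounds shown here showed a ring with a hetero atom and rings with a halogen separately, while compound 4 shows that a ring carrying both chlorine and a hetero atom also gives a half-life that cannot be separated from the other three.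

No measurement shown here explains why these four groups read alike. As far as these compounds go, all four groups are six-membered aromatic rings, so it remains open whether a ring bearing an amine or a carboxylic acid, or a longer alkyl chain on this oxygen, would move the half-life beyond the scatter.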